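Chloromethyl on the acetyl chain: from compound 2 to compound 4

This account rests on a few compounds, and the source may have more. Where it says the series, first, only, none or still open, it means among the compounds named here.

Measured compounds:
compound 1, `COc1cc(NCc2ccccc2)cc(OC)c1OC`, > 80000 nM
compound 2, `COc1ccc(CN(C(C)=O)c2cc(OC)c(OC)c(OC)c2)cc1O`, 160 nM
compound 3, `COc1cc(NCc2cccc(O)c2)cc(OC)c1OC`, 71300 nM

Of the compounds shown here, three sharing a trimethoxy-substituted aniline core have been tested in a functional assay on KYSE-450 cells (Homo sapiens) for inhibition, read by MTT assay, with a stated time of 48 h; on this read-out higher numbers stand for weaker inhibition and lower numbers for stronger inhibition. Compound 1 gives > 80000 nM, which is a limit of the assay and not a number (the limit of > 80000 nM in this assay, at which 1 of the 3 values shown sits). Going by the values given here, compound 3 gives 71300 nM in this assay, and the single measured step, an at least 1.1-fold lower number from compound 1 to compound 3 (0.05 log units; that floor lies within the scatter), stays within the scatter. Compound 2, in which the nitrogen carries an acetyl group, gives 160 nM in this assay; of the two numbers shown it is the lower, and compound 3 sits a long way above it.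

Compound 4, `COc1ccc(CN(C(=O)CCCl)c2cc(OC)c(OC)c(OC)c2)cc1O`, has not yet been measured. It differs from compound 2 in one place: chloromethyl in place of hydrogen on a saturated chain carbon bound to a carbonyl carbon. Among the compounds with values here, no measured step touches the acyl chain, so the data give no direct guide to this change; the only measured step concerns a hydroxy group on an aromatic ring and is small. Compound 4 is therefore expected to stay close to compound 2, with the step of a 1.3-fold higher number from compound 2 to compound 4 (0.10 log units; within the scatter) not expected to exceed the scatter. Compound 4 is estimated at 200 nM in this assay, between 60 nM and 700 nM.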

Compound 4, half-maximal inhibitory concentration: 110 nM
Estimate against measurement, compound 4: 1.8-fold (0.26 log units) above, within the range that was stated.
By their numbers in this assay, from the lowest: compounds 4 and 2 (each within the scatter of the next); then compound 3. At a limit, above all of these: compound 1.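

Going by these compounds alone, this is the first step at the acyl chain on the nitrogen, since the only earlier step concerned a hydroxy group on an aromatic ring. Going from methyl to 2-chloroethyl, with chloromethyl in place of hydrogen on a saturated chain carbon bound to a carbonyl carbon, gives a 1.5-fold lower number from compound 2 to compound 4 (0.16 log units; within the scatter) in this assay, so for this one pair the added chloromethyl leaves the read-out indistinguishable from that of the acetyl compound. Nothing shown here accounts for this outcome or says what role, if any, the chlorine plays.

The pair also cannot separate the chlorine from the extra chain carbon, and a plain ethyl in place of 2-chloroethyl would be needed to tell the two apart. As far as these compounds go, whether this place also accepts a longer chain such as 3-chloropropyl, or a chain ending in an amine or a carboxylic acid, stays open, as does whether a hydroxy group elsewhere on the benzyl ring matters once the nitrogen carries an acyl group.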